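A few compounds are considered here, and "the series" means these few. Any claim that something is new, unique, unknown or untested is made for them only; others in the source may bear on it.

For the measured compounds named here, compound 1 `NCC(O)CNc1cc(N2CCc3ccccc3C2)nc2ccccc12` is one of two compounds measured in an ADME assay on HEp-2 cells (Homo sapiens) for cytotoxicity, read by CCK-8 assay, with a stated time of 5 days (on this read-out lower numbers stand for higher toxicity in this test and higher numbers for lower toxicity in this test), and it stands at the lower of the two numbers: in this assay compound 1 gives 21000 nM. Its companion is compound 2 `OCC(O)CNc1cc(N2CCc3ccccc3C2)nc2ccccc12`, which in this assay gives 66000 nM. Going by the values given here, the one step that links them, a 3.1-fold higher number from compound 1 to compound 2 (0.50 log units; beyond the scatter), is the only measured step and concerns a hydroxy in place of amino on a saturated chain carbon, two bonds along the chain from an oxygen on a saturated carbon.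

Compound 3 `NCCCCNc1cc(N2CCc3ccccc3C2)nc2ccccc12` has not yet been measured in this assay. It differs from compound 1 by 3-aminopropyl in place of 2-amino-1-hydroxyethyl on a saturated chain carbon bound to a nitrogen on an aromatic ring. Among the compounds with values here, the measured step bears on this change only loosely: in the step from compound 1 to compound 2 the amino group was lost, while compound 3 keeps an amino group and instead loses the hydroxy and gains a longer chain, so no measured step speaks to that change directly. Compound 3 is therefore expected to sit close to compound 1, with a step of a 1.2-fold lower number from compound 1 to compound 3 (0.07 log units; within the scatter) that lies within the scatter or only just beyond it. The estimated value of compound 3 in this assay is 18000 nM, between 7000 nM and 45000 nM.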

Compound 3, half-maximal cytotoxic concentration: 7400 nM
For compound 3 the middle estimate is 2.4-fold (0.39 log units) above the measured one; the measured number falls inside the stated range.
By their numbers in this assay, from the lowest: compound 3; then compound 1; then compound 2.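

Putting 3-aminopropyl in place of 2-amino-1-hydroxyethyl on a saturated chain carbon bound to a nitrogen on an aromatic ring lowers the number in this assay (a 2.8-fold lower number from compound 1 to compound 3 (0.45 log units; beyond the scatter)), so this change is not silent even though an amino group stays in the chain, and it moves toward higher toxicity in this test. Compared with the dihydroxy side chain, the same group gives a larger drop (an 8.9-fold lower number from compound 2 to compound 3 (0.95 log units; beyond the scatter)), which shows that, with the core of compound 1 held constant, changes at this position alone span the whole range of the three numbers, with compound 3 now at the low end. Nothing measured here offers a reason for either step.

The compounds shown leave open whether the lower number of compound 3 goes with the loss of the hydroxy or with the longer chain, as both change together in the one step. Also open, on these data alone, is how a still longer chain, a tertiary amine or a carboxylic acid in place of the 3-aminopropyl would read in this test.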